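Swapping thiophene for phenyl on the chalcone carbonyl

The source may report more compounds than this note shows. Statements on the series, on what has been measured and on what is new or still open speak of the compounds shown alone.

All three measured compounds were tested in a functional assay on MCF7 cells (Homo sapiens) for inhibition, read by sulforhodamine B assay, with a stated time of 72 h; a lower number here means a stronger inhibitor, a higher number a weaker inhibitor:
Compound 1 `COc1ccc(C(=O)/C=C/c2cn(-c3ccccc3)nc2-c2ccsc2)cc1OC`: 2800 nM
Compound 2 `COc1ccc(OC)c(C(=O)/C=C/c2cn(-c3ccccc3)nc2-c2ccsc2)c1`: 400 nM
Compound 3 `O=C(/C=C/c1cn(-c2ccccc2)nc1-c1cccnc1)c1ccsc1`: 500 nM

Compound 3 sits second highest of the three numbers. Its value lies within the scatter of compound 2, while compound 1 gives a clearly higher number than compound 3.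

Compound 4 `O=C(/C=C/c1cn(-c2ccccc2)nc1-c1cccnc1)c1ccccc1` has not been measured. It differs from compound 3 by one change: phenyl in place of thiophen-3-yl on a carbonyl carbon. Among the measured compounds shown here, the only measured step, a 7.0-fold lower number from compound 1 to compound 2 (0.85 log units; beyond the scatter), also sits on the carbonyl carbon, but it swaps one methoxy pattern for another and does not show how a thiophene compares with a benzene ring there. For the measured compounds named here, it shows only that the group on the carbonyl carbon can shift the number in this assay by a modest amount.

Going by the values given here, with no direct precedent, the step from compound 3 to compound 4 is expected to stay within the scatter; the estimated step is a 1.2-fold higher number from compound 3 to compound 4 (0.08 log units; within the scatter). Compound 4 is therefore expected to give about 600 nM, in a range from 250 nM to 1500 nM.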

Compound 4, half-maximal inhibitory concentration: 4100 nM
For compound 4 the middle estimate is 6.8-fold (0.83 log units) below the measured one; measured number outside the range, above it.
By their numbers in this assay, from the lowest: compounds 2 and 3 (each within the scatter of the next); then compounds 1 and 4 (each within the scatter of the next).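

In this assay, phenyl in place of thiophen-3-yl on a carbonyl carbon gives an 8.2-fold higher number from compound 3 to compound 4 (0.91 log units; beyond the scatter), so the choice of ring at this position matters. Among the compounds shown here, the earlier step, a 7.0-fold lower number from compound 1 to compound 2 (0.85 log units; beyond the scatter), showed only that moving methoxy groups on a benzene ring there could shift the number. The change swaps a five-membered aromatic ring containing sulfur for a six-membered aromatic ring of carbon only, but no available evidence explains why the number rises.

On these data alone, it remains open whether a furan-3-yl or cyclohexyl group on the carbonyl carbon would give a number closer to that of compound 3 or compound 4. As far as these compounds go, it is also open whether this ring swap would have a similar effect in compounds carrying methoxy groups, such as compound 2.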